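Removing the methyl from an aryl methoxy at the limit

This account rests on a few compounds, and the source may have more. Where it says the series, first, only, none or still open, it means among the compounds named here.

Compound 1 `c1ccc2c(c1)CCCC2CCCN1CCN(C2CCCCC2)CC1` gives > 7500 nM in an assay for binding affinity to Adrenergic receptor alpha-1 (Rattus norvegicus) (a lower number here means a stronger inhibitor, a higher number a weaker inhibitor), a value that is a limit of the assay and not a number.
Compound 2 `COc1ccc2c(c1)CCCC2CCCN1CCN(C2CCCCC2)CC1` gives > 7500 nM in this assay, again a limit rather than a number.
Compound 3 `COc1cccc2c1CCCC2CCCCCCN1CCN(C2CCCCC2)CC1` gives > 7500 nM in this assay, also a limit.

Compound 2 therefore stands at the limit of this assay, and nothing above that limit can be read for it. Among the compounds with values here, the only measured step that differs in one place, the methoxy added on an aromatic carbon from compound 1 to compound 2 a step that the two limits leave unreadable from compound 1 to compound 2, is left unreadable by the two limits, since (the limit of > 7500 nM in this assay, at which 3 of the 3 values shown sit).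

Compound 4 `Oc1ccc2c(c1)CCCC2CCCN1CCN(C2CCCCC2)CC1` differs from compound 2 by hydrogen in place of methyl on an oxygen on an aromatic ring. Within the data shown here, no measured step bears on this change; the one step that touches the same oxygen has no readable size, and every value shown sits at the limit. Compound 4 is accordingly expected to remain weak in this assay, with a step from compound 2 that cannot be read a step that the limit leaves unreadable from compound 2 to compound 4. Compound 4 is estimated at 10000 nM, between 3000 nM and 40000 nM, most probably again as a limit.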

Compound 4, inhibition constant: > 7500 nM
Compound 4: no number, only a limit; the forecaster's own chance of this, stated with the estimate: 75%; the middle value is on the limit's open side.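

In this assay compound 4 gives > 7500 nM, again a limit and not a number. Its steps from compound 1 and compound 2 therefore cannot be read: the limit of > 7500 nM in this assay, at which 4 of the 4 values shown sit.

The compounds shown leave open whether hydrogen, methoxy and hydroxy on the aromatic carbon differ at all in this assay; none of these compounds gives a number.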